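Oxygen substituent variation on the imidazole series

The source may hold more compounds than are shown below. What is called first, only, known or untested is meant among the compounds shown, and "the series" means these compounds.

Compound 1 `CCOC(=O)c1c(C)nc(-c2ccc(OCC(C)C)c(C#N)c2)n1O`: in a functional assay on a cell-free system (plasma, Oryctolagus cuniculus) for inhibition, with stated times of 5 min, 1 min and 6 min (on this read-out lower numbers stand for stronger inhibition and higher numbers for weaker inhibition), compound 1 gives 16800 nM.
Compound 2 `CCOC(=O)c1c(C)nc(-c2ccccc2)n1OC`: compound 2 reaches only the assay limit, > 30000 nM.
Compound 3 `CCOC(=O)COn1c(-c2cccc(C#N)c2)nc(C)c1C(=O)OCC`: in this assay compound 3 gives 6800 nM.

Compound 3 stands lowest of the two numbers given; the nearest is compound 1, whose number is higher by a margin beyond the usual scatter. Compound 2 contributes a limit and no number, as recorded in the limit of > 30000 nM in this assay, at which 1 of the 3 values shown sits.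

Compound 4 `CCOC(=O)c1c(C)nc(-c2cccc(C#N)c2)n1OCc1ccccc1Cl` is not yet measured. It departs from compound 3 by 2-chlorophenyl in place of ethoxycarbonyl on a saturated chain carbon bound to an oxygen on an aromatic ring, the remainder of the shared core unchanged. Within the data shown here, no measured pair shows this kind of change on the oxygen-bound chain carbon, so no step size can be read off; the only guidance is that the nitrile-bearing aryl of compound 3 carries the lowest number. Compound 4 is expected to stay in the same region, with at most a modest shift, the step of a 1.5-fold lower number from compound 3 to compound 4 (0.18 log units; within the scatter) estimated as small. For compound 4 the expected value in this assay is 4500 nM, within 1000 nM to 20000 nM.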

Compound 4, half-maximal inhibitory concentration: 8710 nM
Compound 4: the middle estimate sits 1.9-fold (0.29 log units) below what was measured; the measured number falls inside the stated range.
By their numbers in this assay, from the lowest: compounds 3, 4 and 1 (each within the scatter of the next, the first and the last beyond it). At a limit, above all of these: compound 2.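

Among these compounds, exchanging ethoxycarbonyl for 2-chlorophenyl on a saturated chain carbon bound to an oxygen on an aromatic ring gives a 1.3-fold higher number from compound 3 to compound 4 (0.11 log units; within the scatter) in this assay, the first step that can be read at this place. Within this pair, the place on the chain takes either an ester group with no ring or a six-membered aromatic ring carrying chlorine, and the two compounds read alike. The data shown offer no measurement that explains this likeness.

On these data alone, how a carboxylic acid or an amine on the same chain carbon would read in this assay stays open, as does the reading of a longer chain at this place. Also open, as far as these compounds go, is how plain phenyl would compare with 2-chlorophenyl, so the share of the chlorine cannot be judged.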